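Same aryl swap on a cyclopentyl core: expected maximal response

The compounds below may be only part of what the source reports. "The series", "measured", "known", "first", "only" and "open" are said of these compounds alone.

Measured compounds:
compound 1, `Cc1cc(OCCCCOc2ccc(C(=O)CC(C)C)c(O)c2C)ccc1C(=O)O`, 41.9% in an assay on HEK293 cells for positive allosteric modulation of metabotropic glutamate receptor 3 (Rattus norvegicus), read by thallium flux, with a stated time of 2.5 min; a lower number here means a smaller maximal response, a higher number a larger maximal response
compound 2, `Cc1c(OCCCCOc2ccc(F)c(C(=O)O)c2)ccc(C(=O)CC(C)C)c1O`, 81.7% in this assay
compound 3, `Cc1cc(OCCCCOc2ccc(C(=O)CC3CCCC3)c(O)c2C)ccc1C(=O)O`, 23.7% in this assay

Compound 3 stands lowest of the three in this assay; compound 1 is nearest to it, compound 2 furthest. The difference between compound 1 and compound 2 is 3-carboxy-4-fluorophenyl in place of 4-carboxy-3-methylphenyl on an oxygen on a saturated carbon, and that change brought a number 39.8 percentage points higher from compound 1 to compound 2 (beyond the scatter). Compound 3 differs from compound 1 by cyclopentyl in place of isopropyl on a saturated chain carbon bound to a carbonyl carbon, which went with a number 18.2 percentage points lower from compound 1 to compound 3 (beyond the scatter).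

Compound 4, `Cc1c(OCCCCOc2ccc(F)c(C(=O)O)c2)ccc(C(=O)CC2CCCC2)c1O`, has not been measured in this assay. It is made from compound 3 by 3-carboxy-4-fluorophenyl in place of 4-carboxy-3-methylphenyl on an oxygen on a saturated carbon, the same change that turned compound 1 into compound 2, at the same place. On that basis compound 4 is expected to rise in this assay by a number 38.3 percentage points higher from compound 3 to compound 4 (beyond the scatter), a step of about the size seen as a number 39.8 percentage points higher from compound 1 to compound 2 (beyond the scatter). The starting point for that step is the measured value of compound 3, 23.7%. Whether the step repeats on the cyclopentyl core is not known from the measured compounds, so the expectation is given a broad range. The estimated maximal response of compound 4 is 62%, between 44% and 80%.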

Compound 4, largest response reached (reported as percent of maximum), in percent of the reference or control that the assay uses: 98.4%
Beside the measured number, compound 4's estimate is 36.4 percentage points below it; the measured number lies above the stated range.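

In this assay the exchange of 4-carboxy-3-methylphenyl for 3-carboxy-4-fluorophenyl kept its direction on the core of compound 3, with a number 74.7 percentage points higher from compound 3 to compound 4 (beyond the scatter), but it did not keep its size: the same change on two cores in this assay, a number 39.8 percentage points higher (beyond the scatter) from compound 1 to compound 2 and a number 74.7 percentage points higher (beyond the scatter) from compound 3 to compound 4, 34.9 percentage points apart, beyond the scatter of two such steps. Cyclopentyl in place of isopropyl also depended on its surroundings, lowering the number with 4-carboxy-3-methylphenyl present but giving a number 16.7 percentage points higher from compound 2 to compound 4 (beyond the scatter) with 3-carboxy-4-fluorophenyl present: the same change on two cores in this assay, a number 18.2 percentage points lower (beyond the scatter) from compound 1 to compound 3 and a number 16.7 percentage points higher (beyond the scatter) from compound 2 to compound 4, 34.9 percentage points apart, beyond the scatter of two such steps. The two changes therefore did not act independently across these four compounds, so a step measured on one core gave the direction but not the size on the other, though this single set of four shows neither why the steps differ nor how the change behaves on any further core.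

The compounds shown leave open whether the same dependence appears with another group in place of cyclopentyl, such as cyclohexyl or phenyl. They also leave open what a plain 3-carboxyphenyl without the fluorine, or a longer chain linking the two aryl ethers, would do.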